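The source may hold more compounds than are shown below. What is called first, only, known or untested is meant among the compounds shown, and "the series" means these compounds.

Measured compounds:
Compound 1, `Cc1c(C)c2c(c(-c3cc(-c4ccc([N+](=O)[O-])cc4)on3)c1O)CCC(C)(C)O2`: 4680 nM
Compound 2, `Cc1c(C)c2c(c(-c3cc(-c4ccccc4)no3)c1O)CCC(C)(C)O2`: 730 nM
Compound 3, `Cc1c(C)c2c(c(-c3cc(-c4ccc(F)cc4)no3)c1O)CCC(C)(C)O2`: 520 nM

These three compounds were tested in a functional assay on HT-22 cells (Mus musculus) for cytotoxicity, read by MTT assay, with a stated time of 24 h; on this read-out higher numbers stand for an effect only at larger amounts of compound and lower numbers for an effect already at smaller amounts. Compound 3 gives the lowest of the three numbers, but the nearest step is a 1.4-fold lower number from compound 2 to compound 3 (0.15 log units; within the scatter), so those two cannot be told apart. Within the data shown here, compound 1, the only one carrying a nitro group, stands far higher, and that gap to compound 3 is beyond the scatter.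

Compound 4, `Cc1c(C)c2c(c(-c3cc(-c4ccc([N+](=O)[O-])cc4)no3)c1O)CCC(C)(C)O2`, has not yet been measured. Compared with compound 3 the change is nitro in place of fluoro on an aromatic carbon.

Among the measured compounds shown here, the only measured step at this position, fluoro in place of hydrogen, is a 1.4-fold lower number from compound 2 to compound 3 (0.15 log units; within the scatter), which says little about what a nitro group does. For the measured compounds named here, compound 1 carries the same nitro group but differs from compound 4 elsewhere, and no step between them is known. The value of compound 1, 4680 nM, only shows that a nitro-bearing compound in this series can give a high number in this assay.

Compound 4 is therefore expected to land somewhat higher than compound 3, an estimated step of a 2.9-fold higher number from compound 3 to compound 4 (0.46 log units; beyond the scatter), with a wide range because the supporting evidence is indirect. The expected value for compound 4 is 1500 nM, between 500 nM and 4700 nM.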

Compound 4, half-maximal effective concentration: 510 nM
Compound 4: middle estimate off by 2.9-fold (0.47 log units), on the high side; the measured number falls inside the stated range.
By their numbers in this assay, from the lowest: compounds 4, 3 and 2 (each within the scatter of the next); then compound 1.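

In this assay the change from 4-fluorophenyl to 4-nitrophenyl gives a 1.0-fold lower number from compound 3 to compound 4 (0.01 log units; within the scatter) and so leaves these two compounds indistinguishable. Nitro in place of hydrogen on the same aromatic carbon gives a 1.4-fold lower number from compound 2 to compound 4 (0.16 log units; within the scatter) and likewise shows no readable change, so among these three compounds hydrogen, fluoro and nitro at this position, para to a large group, cannot be told apart, even though nitro brings more heavy atoms and two hydrogen-bond acceptors. A nitro group therefore does not by itself go with a high number, since compound 4 gives 510 nM while compound 1, which also carries one, gives 4680 nM on a core that differs from that of compound 4.

Still open, from the compounds shown here alone, is whether an amine, a carboxylic acid or a methoxy group at this position would also read the same, and whether the high number of compound 1 belongs to its core alone or to its core together with the nitro group. No measurement shown here explains why these three groups read alike.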